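The source may report more compounds than this note shows. Statements on the series, on what has been measured and on what is new or still open speak of the compounds shown alone.

Compound 1 `CCc1ccc(NC2=CC(=O)c3c(nc4n3[C@H]3OC[C@@H](O)[C@H]3OC4)C2=O)cc1`: 1110 nM
Compound 2 `COc1cccc(NC2=CC(=O)c3c(nc4n3[C@H]3OC[C@@H](O)[C@H]3OC4)C2=O)c1`: 1790 nM

Both numbers come from a functional assay on MGC-803 cells (Homo sapiens) for inhibition, read by sulforhodamine B assay; a higher number here means a weaker inhibitor, a lower number a stronger inhibitor. Within the data shown here, the only measured step is a 1.6-fold higher number from compound 1 to compound 2 (0.21 log units; within the scatter), so compound 2 stands level with compound 1 and neither can be ranked. Compound 3 `CCOc1ccccc1NC1=CC(=O)c2c(nc3n2[C@H]2OC[C@@H](O)[C@H]2OC3)C1=O` keeps the shared core and changes the group on the amine nitrogen: 2-ethoxyphenyl in place of 3-methoxyphenyl on an amine nitrogen. This is 2-ethoxyphenyl in place of 3-methoxyphenyl. Among the measured compounds shown here, the one measured swap at this nitrogen, a 1.6-fold higher number from compound 1 to compound 2 (0.21 log units; within the scatter), stayed small, so no step beyond the scatter is expected in this assay. The expected step is a 1.2-fold lower number from compound 2 to compound 3 (0.08 log units; within the scatter). For compound 3 the estimate is 1500 nM, with an expected range of 600 nM to 3800 nM.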

Compound 3, half-maximal inhibitory concentration: 2830 nM
Compound 3: the middle estimate sits 1.9-fold (0.28 log units) below what was measured, and the stated range covers the measured number.
By their numbers in this assay, from the lowest: compounds 1, 2 and 3 (each within the scatter of the next, the first and the last beyond it).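

At the amine nitrogen, 2-ethoxyphenyl in place of 3-methoxyphenyl gives a 1.6-fold higher number from compound 2 to compound 3 (0.20 log units; within the scatter) and so cannot be told apart from ordinary assay noise. Against 4-ethylphenyl, the same group gives a 2.5-fold higher number from compound 1 to compound 3 (0.41 log units; beyond the scatter) in this assay, the only step at this nitrogen so far to clear the scatter, and only modestly. Nothing available here accounts for that difference.

This swap changes both the chain and its place on the ring, so 3-ethoxyphenyl would be needed to separate the two. Going by these compounds, whether a carboxylic acid or an amine on the phenyl ring would shift the number further remains open.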